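A few compounds are considered here, and "the series" means these few. Any claim that something is new, unique, unknown or untested is made for them only; others in the source may bear on it.

Working notes on the series start from compound 1 `COc1ccc(/C=C/C(=O)c2c(O)cc(C)oc2=O)cc1`. In a functional assay on HCT-116 cells (Homo sapiens) for cytotoxicity, read by MTT assay (on this read-out higher numbers stand for weaker inhibition and lower numbers for stronger inhibition), compound 1 gives > 100000 nM, which is a limit of the assay and not a number. Compound 2 `COc1ccc(/C=C/C(=O)c2c(O)cc(C)oc2=O)c(OC)c1` gives > 100000 nM, again a limit. The evidence so far is the limit of > 100000 nM in this assay, at which 2 of the 2 values shown sit. Among the measured compounds shown here, the one measured step, a step that the two limits leave unreadable from compound 1 to compound 2, has no readable size. Compound 3 `Cc1cc(O)c(C(=O)/C=C/c2ccc(C#N)cc2)c(=O)o1` carries cyano in place of methoxy on an aromatic carbon, cyano in place of methoxy on an aromatic carbon, para to a large group. No change beyond the scatter is therefore expected in this assay. The estimated step is a number no higher from compound 1 to compound 3 (the limit leaves the size open). For compound 3 the expected value is 100000 nM, with an estimated range of 30000 nM to 300000 nM.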

Compound 3, half-maximal inhibitory concentration: 66000 nM
Estimate against measurement, compound 3: 1.5-fold (0.18 log units) above; low and high end bracket the measured number.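

In this assay, cyano in place of methoxy on an aromatic carbon, para to a large group, gives an at least 1.5-fold lower number from compound 1 to compound 3 (0.18 log units; that floor lies within the scatter). Among the compounds shown here, compound 3 is the first compound with a number rather than a limit, so a change at this position can bring the read-out within range, though the floor of this step lies within the scatter. The rest of the series remains at the limit: the limit of > 100000 nM in this assay, at which 2 of the 3 values shown sit.

On these data alone, the true size of the step stays open, as compound 1 has only a limit. Also open, as far as these compounds go, is whether an amine or a carboxylic acid in this place would give a value clearly apart from that of compound 3.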